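The source may hold more compounds than are shown below. What is called first, only, known or untested is meant among the compounds shown, and "the series" means these compounds.

Of the compounds shown here, three of one family have been measured in a functional assay on A549 cells (Homo sapiens) for inhibition, read by sulforhodamine B assay; a lower number here means a stronger inhibitor of growth, a higher number a weaker inhibitor of growth. Compound 1 `Cc1ccc2[nH]c(-c3ccc(-c4ccc(-c5ccc(N(C)C)cc5)cc4)cc3)nc2c1` gives 3510 nM there. Compound 2 `Cc1ccc2[nH]c(-c3ccc(-c4ccc(-c5cccc(Cl)c5)cc4)cc3)nc2c1` differs from compound 1 by a single change (3-chlorophenyl in place of 4-(dimethylamino)phenyl on an aromatic carbon), and in this assay compound 2 gives 2800 nM; the step of a 1.3-fold lower number from compound 1 to compound 2 (0.10 log units; within the scatter). Compound 3 `CN(C)c1ccc(-c2ccc(-c3ccc(-c4nc5ccccc5[nH]4)cc3)cc2)cc1` carries the same 4-(dimethylamino)phenyl group as compound 1 but has a different core (hydrogen in place of methyl on an aromatic carbon). In this assay compound 3 gives 30100 nM, and the step of an 8.6-fold higher number from compound 1 to compound 3 (0.93 log units; beyond the scatter), so compound 3 stands with the highest number of the three, beyond the scatter from both compound 1 and compound 2.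

Compound 4 `Clc1cccc(-c2ccc(-c3ccc(-c4nc5ccccc5[nH]4)cc3)cc2)c1` has not yet been measured. It differs from compound 3 by 3-chlorophenyl in place of 4-(dimethylamino)phenyl on an aromatic carbon, the same change that separates compound 2 from compound 1, here made on the core of compound 3 rather than on the core of compound 1. For the measured compounds named here, there is only this one precedent, and it hardly moved the number. The step from compound 3 to compound 4 is therefore expected to be a 1.3-fold lower number from compound 3 to compound 4 (0.12 log units; within the scatter), because a 1.3-fold lower number from compound 1 to compound 2 (0.10 log units; within the scatter) lay within the scatter. On that footing compound 4 is estimated at 23000 nM in this assay. The likely range for compound 4 is expected to run from 10000 nM to 55000 nM, wide enough to allow that the change on the core of compound 3 need not repeat what it did on the core of compound 1.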

Compound 4, concentration for 50% growth inhibition: 31100 nM
For compound 4 the middle estimate is 1.4-fold (0.13 log units) below the measured one; low and high end bracket the measured number.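

In this assay, 3-chlorophenyl in place of 4-(dimethylamino)phenyl on the core of compound 3 gives a 1.0-fold higher number from compound 3 to compound 4 (0.01 log units; within the scatter), so this exchange leaves the number as little moved as it did on the core of compound 1: the same change on two cores in this assay, a 1.3-fold lower number (0.10 log units; within the scatter) from compound 1 to compound 2 and a 1.0-fold higher number (0.01 log units; within the scatter) from compound 3 to compound 4, 1.3-fold (0.11 log units) apart, within the scatter of two such steps. Hydrogen in place of methyl, read here with 3-chlorophenyl present, gives an 11-fold higher number from compound 2 to compound 4 (1.05 log units; beyond the scatter), and this step keeps its size whichever of the two groups is present: the same change on two cores in this assay, an 8.6-fold higher number (0.93 log units; beyond the scatter) from compound 1 to compound 3 and an 11-fold higher number (1.05 log units; beyond the scatter) from compound 2 to compound 4, 1.3-fold (0.11 log units) apart, within the scatter of two such steps. Across these four compounds the two changes therefore behave independently, but this rests on one pair of groups and one pair of cores, and it shows neither that other groups would carry over in the same way nor why the methyl matters.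

The compounds shown leave open whether a group other than these two, such as a carboxylic acid or an amine on a longer chain, would also leave the number unmoved on either core. They also leave open whether the step between the two cores is specific to methyl or would also appear with chlorine or methoxy in its place.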